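The source may hold more compounds than are shown below. What is called first, only, known or untested is meant among the compounds shown, and "the series" means these compounds.

Working notes on the series.

Compounds 1 and 2 share one core; compound 1 is `Cc1ccccc1-c1cccc(COc2ccc(S(=O)(=O)CC(=O)O)cc2)c1` and compound 2 is `O=C(O)CS(=O)(=O)c1ccc(OCc2cccc(-c3ccccc3Cl)c2)cc1`. In a functional assay on CHO cells for agonist activity at Free fatty acid receptor 1 (Homo sapiens), read by FLIPR and calcium flux (a lower number here means that less compound is needed, a higher number that more compound is needed for the effect), compound 2 gives 28.8 nM, and in this assay compound 1 gives 46.8 nM. The change between them is methyl in place of chloro on an aromatic carbon and the step it made is a 1.6-fold higher number from compound 2 to compound 1 (0.21 log units; within the scatter), so the two compounds cannot be placed in any order on this evidence.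

Compound 3 is `Cc1nc(-c2cccc(Cl)c2)sc1COc1ccc(S(=O)(=O)CC(=O)O)cc1` and stands on a different core; the difference between the two cores is not broken down here. In this assay compound 3 gives 251 nM, the highest of the three numbers, beyond the scatter from both compound 1 and compound 2.

Compound 4, `Cc1cccc(-c2nc(C)c(COc3ccc(S(=O)(=O)CC(=O)O)cc3)s2)c1`, not yet measured, is compound 3 with methyl in place of chloro on an aromatic carbon. This is the same kind of change as from compound 2 to compound 1, not the same: there the group sits ortho to a large group, here meta to a large group, and the core carrying the phenyl ring is another one. Within the data shown here, the only direct reading of this change is the step from compound 2 to compound 1, which is a 1.6-fold higher number from compound 2 to compound 1 (0.21 log units; within the scatter) and within the scatter, so the expected step from compound 3 to compound 4 is likewise small, a 1.3-fold higher number from compound 3 to compound 4 (0.11 log units; within the scatter), resting on that single pair. Compound 4 is expected in this assay near 320 nM, with a plausible spread from 120 nM to 850 nM; the different position and core leave this expectation loosely held.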

Compound 4, half-maximal effective concentration: 214 nM
Compound 4: the middle estimate sits 1.5-fold (0.17 log units) above what was measured; measured number inside the range.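

In this assay, methyl in place of chloro on the phenyl ring of the second core gives a 1.2-fold lower number from compound 3 to compound 4 (0.07 log units; within the scatter), so these two compounds cannot be placed in any order. Set beside the earlier pair on the first core, this step shows no difference in how the change reads on the two cores: the same change on two cores in this assay, a 1.6-fold higher number (0.21 log units; within the scatter) from compound 2 to compound 1 and a 1.2-fold lower number (0.07 log units; within the scatter) from compound 3 to compound 4, 1.9-fold (0.28 log units) apart, within the scatter of two such steps On this evidence, the exchange of chloro for methyl can be carried from one core to the other as a change that stays within the scatter, but this rests on just two pairs, in which the place of the group on the ring differs along with the core, so the two influences cannot be separated, and the result does not show that the same would hold on any further core.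

The compounds shown carry only chloro or methyl on the outer phenyl ring, which leaves open whether a trifluoromethyl, a methoxy, a nitrile or an amine there would also read alike on both cores. Going by these compounds, all four compounds also keep the same sulfonyl acetic acid chain, so it remains open how a tetrazole or an amide in place of the carboxylic acid, or a longer chain, would read in this assay.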